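Formyl to oxime on the shared core: compound 4

The source may report more compounds than this note shows. Statements on the series, on what has been measured and on what is new or still open speak of the compounds shown alone.

Measured so far:
compound 1, `Cc1ccc2c(Cc3nn4c(C=O)c(-c5ccc(Cl)cc5)nc4s3)coc2c1`, 48.8%
compound 2, `Cc1ccc2c(Cc3nn4c(C=O)c(-c5ccc(Br)cc5)nc4s3)coc2c1`, 12.4%
compound 3, `Cc1ccc2c(Cc3nn4c(CO)c(-c5ccc(Br)cc5)nc4s3)coc2c1`, 47.3%

In a functional assay on the whole organism (strain Wistar albino) for inhibition, with Rattus norvegicus as the target, read by paw edema, with a stated time of 5 h, at a dose of 100 mg/kg by the oral route (on this read-out lower numbers stand for less inhibition and higher numbers for more inhibition at the one dose given (going by the name of the read-out)), compound 1 gives the top number of the three, though compound 3 sits within the scatter of it and only compound 2 lies beyond. Two single-point steps are on record. a number 36.4 percentage points lower from compound 1 to compound 2 (beyond the scatter). a number 34.9 percentage points higher from compound 2 to compound 3 (beyond the scatter).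

Compound 4, `Cc1ccc2c(Cc3nn4c(/C=N/O)c(-c5ccc(Cl)cc5)nc4s3)coc2c1`, is not yet measured. It differs from compound 1 in this way: a group of 3 heavy atoms (1 carbon, 1 nitrogen, 1 oxygen; no ring) in place of a group of 2 heavy atoms (1 carbon, 1 oxygen; no ring), on an aromatic carbon. Going by the values given here, the only measured step that touches this position is the one from compound 2 to compound 3, where the formyl group was exchanged on the same aromatic carbon and the number moved by a large amount, upward. That step was taken on the bromo compound and led to hydroxymethyl rather than to the group entering here, so it gives direction only loosely. The halogen step from compound 1 to compound 2 does not bear on the change at hand.

Compound 1 already stands at the top of the measured range, so the expected step of a number 1.2 percentage points higher from compound 1 to compound 4 (within the scatter) is small, with no direction beyond the scatter. Compound 4 is therefore estimated at 50%, between 35% and 65%.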

Compound 4, a percentage reported as inhibition, in the whole organism at one dose (the size of the read-out at that dose, not a potency): 31%
Beside the measured number, compound 4's estimate is 19 percentage points above it; the whole stated range lies above it.
By their numbers in this assay, from the lowest: compound 2; then compound 4; then compounds 3 and 1 (each within the scatter of the next).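

In this assay, the oxime in place of formyl on the aromatic carbon gives a number 17.8 percentage points lower from compound 1 to compound 4 (beyond the scatter), so leaving formyl at this position does not by itself raise the number. The only earlier exchange here, hydroxymethyl in place of formyl on the bromo compound, gave a number 34.9 percentage points higher from compound 2 to compound 3 (beyond the scatter), so the two exchanges run in opposite directions and the outcome at this position depends on the entering group, the halogen on the aromatic ring, or both; with the two exchanges taken on different halogens, the compounds shown cannot separate these. No measurement on hand accounts for the drop seen with the oxime.

Still open, on these data alone, is whether the two exchanges keep their directions on a common halogen, that is, how hydroxymethyl behaves with the 4-chlorophenyl group and the oxime with its bromo counterpart. Also open, as far as these compounds go, is what a carboxylic acid, an aminomethyl group or a longer hydroxyalkyl chain on this aromatic carbon would give in this assay.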